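Iodo for bromo on a free aniline chalcone

This account rests on a few compounds, and the source may have more. Where it says the series, first, only, none or still open, it means among the compounds named here.

Measured so far:
compound 1 `C=C(Br)C(=O)Nc1ccc(/C=C/C(=O)c2ccc(Br)cc2)cc1` — 620 nM
compound 2 `C=C(Br)C(=O)Nc1ccc(/C=C/C(=O)c2ccc(I)cc2)cc1` — 3400 nM
compound 3 `Nc1ccc(/C=C/C(=O)c2ccc(Br)cc2)cc1` — 90000 nM

All three were tested in a functional assay on L1210 cells (Mus musculus) for antiproliferative activity, with a stated time of 48 h; on this read-out lower numbers stand for stronger inhibition and higher numbers for weaker inhibition. Compound 1 gives 620 nM, and compound 3 gives 90000 nM. Compound 4 `Nc1ccc(/C=C/C(=O)c2ccc(I)cc2)cc1` is not yet measured.

Compounds 1 and 2 differ in one place, (iodo in place of bromo on an aromatic carbon), and that change gave a 5.5-fold higher number from compound 1 to compound 2 (0.74 log units; beyond the scatter). The change from compound 3 to compound 4 is iodo in place of bromo on an aromatic carbon, the same change made on a different core. The two cores differ by hydrogen in place of (1-bromoethenyl)carbonyl on a nitrogen on an aromatic ring, a change that gave a 150-fold higher number from compound 1 to compound 3 (2.16 log units; beyond the scatter), so the core of compound 3 already stands far weaker in this assay.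

Going by the values given here, for compound 4 the expectation is a step of about a 3.3-fold higher number from compound 3 to compound 4 (0.52 log units; beyond the scatter) in this assay, resting on the single earlier instance of the same change, in which compound 1 moved to compound 2 by a 5.5-fold higher number from compound 1 to compound 2 (0.74 log units; beyond the scatter). Because compound 3 starts from 90000 nM, compound 4 is expected to land at roughly 300000 nM, plausibly between 100000 nM and 1000000 nM.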

Compound 4, half-maximal inhibitory concentration: 50000 nM
Beside the measured number, compound 4's estimate is 6.0-fold (0.78 log units) above it, outside the stated range (below it).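

In this assay, iodo in place of bromo gave a 1.8-fold lower number from compound 3 to compound 4 (0.26 log units; within the scatter), so on the core of compound 3 the two halogens cannot be told apart, while the same change on the core of compound 1 gave a clear step: the same change on two cores in this assay, a 5.5-fold higher number (0.74 log units; beyond the scatter) from compound 1 to compound 2 and a 1.8-fold lower number (0.26 log units; within the scatter) from compound 3 to compound 4, 9.9-fold (0.99 log units) apart, beyond the scatter of two such steps. Seen from the other side, hydrogen in place of the (1-bromoethenyl)carbonyl group on the nitrogen gave a 15-fold higher number from compound 2 to compound 4 (1.17 log units; beyond the scatter) in the iodo pair, a smaller step than in the bromo pair: the same change on two cores in this assay, a 150-fold higher number (2.16 log units; beyond the scatter) from compound 1 to compound 3 and a 15-fold higher number (1.17 log units; beyond the scatter) from compound 2 to compound 4, 9.9-fold (0.99 log units) apart, beyond the scatter of two such steps. Going by these compounds alone, the size of the halogen change therefore did not carry from one core to the other, but this rests on only two pairs and does not show why the steps differ.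

Going by these compounds, it remains open how chloro or a plain hydrogen on that aromatic carbon would behave on either core. On these data alone, it is also open whether an acetyl group on the nitrogen would give the same dependence on the halogen as the (1-bromoethenyl)carbonyl group does.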